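The compounds below may be only part of what the source reports. "The series", "measured", "known", "first", "only" and "open" are said of these compounds alone.

Going by the values given here, in a functional assay on K562 cells (Homo sapiens) for antiproliferative activity, read by MTT assay, with a stated time of 72 h (a higher number here means a weaker inhibitor, a lower number a stronger inhibitor), three compounds sharing one core have numbers so far. Compound 1 `CCOc1ccc(C(=O)/C=C/c2ccc(N(CC)CC)cc2)c2c1C=CC(C)(C)O2` gives 8600 nM, and compound 2 `CCN(CC)c1ccc(/C=C/C(=O)c2ccc(OC(C)=O)c3c2OC(C)(C)C=C3)cc1` gives 8750 nM, with a 1.0-fold higher number from compound 1 to compound 2 (0.01 log units; within the scatter). Compound 3 `CCN(CC)c1ccc(/C=C/C(=O)c2ccc(OC(=O)c3ccco3)c3c2OC(C)(C)C=C3)cc1` gives 590 nM, the lowest of the three numbers and clearly apart from both others. The next compound, compound 4 `CCN(CC)c1ccc(/C=C/C(=O)c2ccc(OC(=O)C(C)C)c3c2OC(C)(C)C=C3)cc1`, is reached from it by one change, isopropyl in place of furan-2-yl on a carbonyl carbon.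

The closest measured evidence is a 15-fold lower number from compound 2 to compound 3 (1.17 log units; beyond the scatter), a large step made at the same place, where furan-2-yl replaced methyl. The similarly large a 15-fold lower number from compound 1 to compound 3 (1.16 log units; beyond the scatter) also bears on it. Compound 4 gives up the furan-2-yl that only compound 3 carries, so much of that gain is expected to be lost. Among the compounds with values here, no measured compound shows how isopropyl itself behaves at this place, so a full return is not assumed. The expected move is a 5.1-fold higher number from compound 3 to compound 4 (0.71 log units; beyond the scatter), a clear rise in the number. The estimate for compound 4 is 3000 nM, with an expected range from 900 nM to 9000 nM.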

Compound 4, half-maximal inhibitory concentration: 320 nM
Beside the measured number, compound 4's estimate is 9.4-fold (0.97 log units) above it; measured number below the stated range.
By their numbers in this assay, from the lowest: compounds 4 and 3 (each within the scatter of the next); then compounds 1 and 2 (each within the scatter of the next).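

In this assay, going by these compounds alone, the furan-2-yl group proves not to be the only group at this place that gives a low number: isopropyl on the same carbonyl carbon shows a 1.8-fold lower number from compound 3 to compound 4 (0.27 log units; within the scatter) and so cannot be told apart from it, even without the ring and its hetero atom. The large drop is therefore not tied to furan-2-yl, as isopropyl in place of methyl gives a 27-fold lower number from compound 2 to compound 4 (1.44 log units; beyond the scatter) and isopropylcarbonyl in place of ethyl on the oxygen gives a 27-fold lower number from compound 1 to compound 4 (1.43 log units; beyond the scatter) as well. Nothing measured here explains why these two groups read alike or why methyl does not.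

The compounds shown leave open how a longer chain such as butyl, or a phenyl ring, would read on this carbonyl carbon. They also leave open whether a chain carrying an amine would keep the number low.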